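The source may report more compounds than this note shows. Statements on the series, on what has been measured and on what is new or still open speak of the compounds shown alone.

Compound 1 `O=C(NCCCCc1ccccc1)n1cnc2ccccc21` gives > 2 h in a physicochemical assay for metabolic stability, read by HPLC, at pH 4.5, tested at 10 uM (a lower number here means that the compound disappears faster, a higher number that the compound lasts longer), and this reading is a limit of the assay, not a number. Where compound 1 has hydrogen on an aromatic carbon, compound 2 `Nc1nc2ccccc2n1C(=O)NCCCCc1ccccc1` carries amino, and in this assay compound 2 gives 0.717 h, the only actual number so far. The next structure, compound 3 `Cc1nc2ccccc2n1C(=O)NCCCCc1ccccc1`, has methyl in place of amino on that aromatic carbon, between two ring nitrogen atoms: methyl in place of amino on an aromatic carbon. Among the compounds with values here, only one measured step bears on this change: an at least 2.7-fold lower number from compound 1 to compound 2 (0.44 log units; beyond the scatter), when amino replaced hydrogen. Within the data shown here, no measured compound yet carries methyl, so that step is only a rough guide. With amino gone again, part of that drop may be recovered, and a modest rise is expected. The expected step is a 2.1-fold higher number from compound 2 to compound 3 (0.32 log units; beyond the scatter). Compound 3 is estimated at 1.5 h, within an expected range of 0.6 h to 4 h.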

Compound 3, half-life: 0.133 h
Estimate against measurement, compound 3: 11-fold (1.05 log units) above, and the stated range ends above it.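

In this assay, putting methyl where compound 2 has amino, on this aromatic carbon between two ring nitrogen atoms, does not bring back the longer life of compound 1: the change instead gives a 5.4-fold lower number from compound 2 to compound 3 (0.73 log units; beyond the scatter) and makes compound 3 the shortest-lived of the three. Methyl in place of hydrogen gives an at least 15-fold lower number from compound 1 to compound 3 (1.17 log units; beyond the scatter) and shows that the lower number at this position does not depend on amino alone. Within the data shown here, compound 1 is the one compound whose reading is a limit, so the full size of both drops from it remains unknown: the limit of > 2 h in this assay, at which 1 of the 3 values shown sits.

The compounds shown do not tell why methyl falls so far below amino. Going by these compounds, whether this short life is particular to methyl remains open, and a longer chain such as ethyl, or a methoxy group or chlorine on the same carbon, would help to show it.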